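The source may hold more compounds than are shown below. What is called first, only, known or untested is meant among the compounds shown, and "the series" means these compounds.

Compound 2, `C/C(=N/O)c1ccc(NC(=O)Cn2nc(-c3ccccc3)nc2N)cc1`, gives the lowest of the two numbers in a functional assay on CCRF-CEM cells (Homo sapiens) for inhibition, read by sulforhodamine B assay, with a stated time of 48 h, tested at 10 uM; a higher number here means more inhibition of growth at the concentration tested, a lower number less inhibition of growth; compound 2 reaches 6.77%, while compound 1, `C/C(=N\O)c1ccc(NC(=O)Cn2nc(-c3ccc(Cl)cc3)nc2N)cc1`, reaches 14.7%, a gap that stays within the scatter. Compound 3, `C/C(=N/O)c1ccc(NC(=O)Cn2nc(C(F)(F)F)nc2N)cc1`, differs from compound 2 by trifluoromethyl in place of phenyl on an aromatic carbon. Within the data shown here, no measured pair shows this change, so the expectation rests on the low numbers of both measured compounds alone. The step of a number 2.2 percentage points higher from compound 2 to compound 3 (within the scatter) is expected to be small, with no direction beyond the scatter. Compound 3 is estimated at 9%, within a range from 0% to 22%.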

Compound 3, percent growth inhibition at one concentration: 10.5%
Estimate against measurement, compound 3: 1.5 percentage points below; low and high end bracket the measured number.
By their numbers in this assay, from the lowest: compounds 2, 3 and 1 (each within the scatter of the next).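

In this assay, the step of a number 3.7 percentage points higher from compound 2 to compound 3 (within the scatter) shows that compound 2 and compound 3 cannot be told apart, although trifluoromethyl replaces phenyl on this aromatic carbon and the six-membered aromatic ring is lost. Within this pair, therefore, a large ring on this carbon is not needed to keep the reading seen with phenyl, which is low in both compounds. No measurement at hand explains this result. From the compounds shown here alone, it remains open whether an amine or a carboxylic acid on this carbon would give a step beyond the scatter. The compounds shown also leave open whether any group here can lift growth inhibition well above these low readings.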